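Aryl sulfonyl indoles: fluoro in place of ring methoxy

The compounds below may be only part of what the source reports. "The series", "measured", "known", "first", "only" and "open" are said of these compounds alone.

Measured in an assay on HeLa cells for binding affinity to 5-hydroxytryptamine receptor 6 (Homo sapiens); a lower number here means a stronger inhibitor, a higher number a weaker inhibitor:
compound 1 `NCCn1cc(S(=O)(=O)c2ccccc2)c2ccccc21` gives 25 nM
compound 2 `CNCCn1cc(S(=O)(=O)c2ccccc2)c2ccccc21` gives 15.5 nM
compound 3 `COc1ccc2c(S(=O)(=O)c3ccccc3)cn(CCN(C)C)c2c1` gives 23 nM

Within the data shown here, compound 3 sits between the other two numbers, and both gaps are within the scatter, as is the one measured step, a 1.6-fold lower number from compound 1 to compound 2 (0.21 log units; within the scatter), which concerns the amine nitrogen only. Compound 4 `CN(C)CCn1cc(S(=O)(=O)c2ccccc2)c2ccc(F)cc21` differs from compound 3 by fluoro in place of methoxy on an aromatic carbon. Among the measured compounds shown here, no measured pair changes a substituent on the aromatic ring, so nothing in this assay speaks directly to the step; the series as a whole spans less than the scatter. Compound 4 is therefore expected to give a step of a 1.1-fold higher number from compound 3 to compound 4 (0.04 log units; within the scatter), that is, none beyond the scatter. The estimate for compound 4 in this assay is 25 nM, with a range from 9 nM to 70 nM.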

Compound 4, inhibition constant: 46 nM
Compound 4: middle estimate off by 1.8-fold (0.26 log units), on the low side; low and high end bracket the measured number.
By their numbers in this assay, from the lowest: compounds 2, 3, 1 and 4 (each within the scatter of the next, the first and the last beyond it).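

In this assay, fluoro in place of methoxy on this aromatic carbon gives a 2.0-fold higher number from compound 3 to compound 4 (0.30 log units; within the scatter) and so stays within the scatter, though only just. Among these compounds, this is the only measured pair that changes a substituent on the aromatic ring, and it shows that this carbon accepts the smaller fluoro with no step beyond the scatter. No supporting data bear on this step.

Still open, as far as these compounds go, is whether chloro, hydroxy or nitrile on this carbon would stay within the scatter of compound 3. Also open, from the compounds shown here alone, is whether replacing a methyl on the amine nitrogen with hydrogen changes the reading when fluoro is on the ring.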